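Dropping a Chloro Group from a Weak Cytotoxic Ketone

This account rests on a few compounds, and the source may have more. Where it says the series, first, only, none or still open, it means among the compounds named here.

Compound 1, `O=C(c1cccnc1)c1ccccc1O`, gives 33700 nM in a functional assay on IMR-32 cells (Homo sapiens) for cytotoxicity, read by sulforhodamine B assay, with a stated time of 48 h; a lower number here means a stronger inhibitor, a higher number a weaker inhibitor.
Compound 2, `O=C(c1cccnc1)c1cccc(Cl)c1O`, gives 26000 nM.
Compound 3, `C=CCOc1ccc(Cl)cc1C(=O)c1cccnc1`, gives 91000 nM.

Compound 3 has the highest number of the three, beyond the scatter against both compound 1 and compound 2. The difference between the core of compound 2 and the core of compound 3 is not broken down here. Going from compound 2 to compound 1 the change is hydrogen in place of chloro on an aromatic carbon, and it made a step of a 1.3-fold higher number from compound 2 to compound 1 (0.11 log units; within the scatter). Compound 4, `C=CCOc1ccccc1C(=O)c1cccnc1`, arises from compound 3 by hydrogen in place of chloro on an aromatic carbon. This is the same kind of change, though the place differs: ortho to a hydroxy group in the measured pair, para to an allyloxy group here. Because a 1.3-fold higher number from compound 2 to compound 1 (0.11 log units; within the scatter) was within the scatter, a similarly small step is expected for a 1.0-fold higher number from compound 3 to compound 4 (0.02 log units; within the scatter). Compound 4 is therefore estimated at 95000 nM in this assay.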

Compound 4, half-maximal inhibitory concentration: 44000 nM
Compound 4: the middle estimate sits 2.2-fold (0.33 log units) above what was measured, and the stated range ends above it.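

Replacing chloro with hydrogen in this assay gives a 2.1-fold lower number from compound 3 to compound 4 (0.32 log units; beyond the scatter), and this step does not carry over unchanged from one core to the other: the same change on two cores in this assay, a 1.3-fold higher number (0.11 log units; within the scatter) from compound 2 to compound 1 and a 2.1-fold lower number (0.32 log units; beyond the scatter) from compound 3 to compound 4, 2.7-fold (0.43 log units) apart, beyond the scatter of two such steps. The chloro group also sits in a different place on the two cores, so these pairs cannot separate the effect of the core from the effect of that place, and they do not show why the steps differ. Allyl in place of hydrogen on the oxygen gives a 1.3-fold higher number from compound 1 to compound 4 (0.12 log units; within the scatter), so this change makes no clear difference when no chloro group is present, but that is a single pair.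

Going by these compounds, whether the same allyl change would behave alike with a chloro group present remains open. So does the effect of a longer chain on that oxygen, or of a fluoro or amine group in place of the chloro group.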